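Replacing Methylsulfonyl with Fluoro on the Aryl Ether

The source may report more compounds than this note shows. Statements on the series, on what has been measured and on what is new or still open speak of the compounds shown alone.

Three measured compounds share one core and differ only in a single group on the same aromatic ring. Compound 1 `Cc1cc(COc2cccc(Cl)c2)nc(-c2ccccn2)n1` carries a chloro there, and in a functional assay on cells for antagonist activity at Free fatty acid receptor 1 (Homo sapiens), read by TR-FRET and inositol phosphate accumulation, with a stated time of 2 h (a higher number here means a weaker inhibitor, a lower number a stronger inhibitor), compound 1 gives 398 nM. Compound 2 `COc1cccc(OCc2cc(C)nc(-c3ccccn3)n2)c1` carries a methoxy, and in this assay compound 2 gives 2000 nM. Compound 3 `Cc1cc(COc2cccc(S(C)(=O)=O)c2)nc(-c2ccccn2)n1` carries a methylsulfonyl. In this assay compound 3 gives > 39800 nM, which is a limit of the assay and not a number (the limit of > 39800 nM in this assay, at which 1 of the 3 values shown sits). Compound 3 therefore stands at the weak end of the three: an at least 100-fold higher number from compound 1 to compound 3 (2.00 log units; beyond the scatter), and an at least 19-fold higher number from compound 2 to compound 3 (1.29 log units; beyond the scatter). The smaller move between the other two, a 5.0-fold higher number from compound 1 to compound 2 (0.70 log units; beyond the scatter), points the same way.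

Compound 4 `Cc1cc(COc2cccc(F)c2)nc(-c2ccccn2)n1` arises from compound 3 by fluoro in place of methylsulfonyl on an aromatic carbon. The two steps that bear on this change are the ones that led into compound 3, and both were large, so undoing the methylsulfonyl is expected to reverse most of that loss. Fluoro, like chloro, is a single halogen atom, so compound 4 is expected to land near compound 1 in this assay, giving an estimated 800 nM, with a range from 250 nM to 3000 nM. The expected step is an at least 49-fold lower number from compound 3 to compound 4 (1.69 log units; beyond the scatter).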

Compound 4, half-maximal inhibitory concentration: 794 nM
Estimate against measurement, compound 4: 1.0-fold (0.00 log units) above; the range from low to high includes it.
By their numbers in this assay, from the lowest: compounds 1 and 4 (each within the scatter of the next); then compound 2. At a limit, above all of these: compound 3.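

In this assay, fluoro behaves like chloro at this position and not like methoxy: a 2.0-fold higher number from compound 1 to compound 4 (0.30 log units; within the scatter), so the data cannot separate the two halogens, whereas a 2.5-fold lower number from compound 2 to compound 4 (0.40 log units; beyond the scatter), which is a real if modest difference. The largest step, an at least 50-fold lower number from compound 3 to compound 4 (1.70 log units; beyond the scatter), shows that the shared core keeps its activity once methylsulfonyl is gone, so the loss seen with methylsulfonyl belongs to that group and this position, not to the rest of the molecule. The true size of that step stays unknown, since compound 3 gives a limit of the assay and not a number: the limit of > 39800 nM in this assay, at which 1 of the 4 values shown sits.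

Going by these compounds, how a bare hydrogen, a methyl or a bromo would compare at this place remains open, as does whether an amine or a carboxylic acid would sit with the halogens or with methylsulfonyl. All four compounds also carry their group at the same place on the ring, so what fluoro would do elsewhere on that ring is an open question too.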